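The source may report more compounds than this note shows. Statements on the series, on what has been measured and on what is new or still open speak of the compounds shown alone.

Measured so far:
Compound 1, `COc1ccc(CNC(=O)CSc2nc3ccc(NC(=O)c4ccc(Cl)cc4)cc3s2)cc1`: 19200 nM
Compound 2, `O=C(CSc1nc2ccc(NC(=O)c3ccc([N+](=O)[O-])cc3)cc2s1)NCc1ccccc1`: > 100000 nM

Of the compounds shown here, two have been measured in a functional assay on MCF7 cells (Homo sapiens) for cytotoxicity, read by MTT assay, with a stated time of 48 h; a higher number here means a weaker inhibitor, a lower number a stronger inhibitor. Compound 1 gives 19200 nM. For compound 2 the assay reports only a limit, > 100000 nM, and no number; compound 2 therefore stands at the limit of this assay, a point described by the limit of > 100000 nM in this assay, at which 1 of the 2 values shown sits. The two compounds differ in two places, so their values are set side by side without a single step drawn between them.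

The next compound, compound 3 with the structure `COc1ccc(CNC(=O)CSc2nc3ccc(NC(=O)c4ccc([N+](=O)[O-])cc4)cc3s2)cc1`, has not yet been measured. It differs from compound 2 in one place: methoxy in place of hydrogen on an aromatic carbon. Among the measured compounds shown here, no measured step covers this change alone, so its size in this assay is not known from the numbers at hand. For the measured compounds named here, compound 1, which carries the same methoxy group together with a different substituent on the amide ring, gives the one numerical value available.

Compound 3 is expected to give about 50000 nM, within a range from 10000 nM to 200000 nM. The step that is expected from this estimate is an at least 2.0-fold lower number from compound 2 to compound 3 (0.30 log units; that floor lies within the scatter).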

Compound 3, half-maximal inhibitory concentration: > 100000 nM
Compound 3 gave a limit, no number (the forecaster's own chance of this, stated with the estimate: 50%); middle value at least 2.0-fold (0.30 log units) from the limit.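

In this assay, with the 4-methoxybenzyl group kept in both compounds, nitro in place of chloro on an aromatic carbon gives an at least 5.2-fold higher number from compound 1 to compound 3 (0.71 log units; beyond the scatter). Among the compounds shown here, the earlier pair differed in two places, so this is the one change here whose effect can be read alone, and it shows that the chloro compound sits clearly apart from its nitro counterpart. The methoxy group does not bring the nitro compound back to a number, but the size of its step cannot be read, because compound 2 and compound 3 both stand at a limit: the limit of > 100000 nM in this assay, at which 2 of the 3 values shown sit.

On these data alone, whether methoxy in place of hydrogen has any effect at all therefore remains open, since it would show only in a pair that gives numbers on both sides, such as compound 1 and its counterpart with a plain benzyl group. As far as these compounds go, it also remains open how far the value depends on this substituent, for instance whether an amine or a carboxylic acid in place of chloro or nitro on that aromatic carbon would give a number in this assay.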